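Borate series: removing one aromatic fluoro from compound 3

The compounds below may be only part of what the source reports. "The series", "measured", "known", "first", "only" and "open" are said of these compounds alone.

Three compounds carry numbers in an assay on HEK293 cells for inhibition of transient receptor potential cation channel subfamily V member 6 (Homo sapiens), read by FLIPR and calcium flux, with a stated time of 5 min; on this read-out higher numbers stand for weaker inhibition and lower numbers for stronger inhibition. Compound 1 `NCCOC(c1ccccc1)c1ccccc1` gives 159000 nM; compound 2 `OB(c1ccc(C(F)(F)F)cc1)c1ccc(C(F)(F)F)cc1` gives 10800 nM; compound 3 `Fc1ccc([B-]2(c3ccc(F)cc3)[NH2+]CCO2)cc1` gives 17000 nM. Compound 3 stands second highest of the three: compound 2 is nearest, and the gap between the two lies within the scatter, while compound 1 is furthest and that gap lies beyond the scatter. Compound 4 `Fc1ccc([B-]2(c3ccccc3)[NH2+]CCO2)cc1` differs from compound 3 by hydrogen in place of fluoro on an aromatic carbon. Among the compounds with values here, no step between measured compounds resembles this change, so expectation rests on compound 3 alone. Expected is a small step, a 1.3-fold higher number from compound 3 to compound 4 (0.11 log units; within the scatter), toward a higher number that stays within the scatter. Compound 4 is expected to give about 22000 nM, within 9000 nM to 55000 nM.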

Compound 4, half-maximal inhibitory concentration: 18800 nM
Compound 4: middle estimate off by 1.2-fold (0.07 log units), on the high side; measured number inside the range.
By their numbers in this assay, from the lowest: compounds 2, 3 and 4 (each within the scatter of the next); then compound 1.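

Within the data shown here, on this assay the step of a 1.1-fold higher number from compound 3 to compound 4 (0.04 log units; within the scatter) gives the first one-place comparison: hydrogen in place of fluoro on an aromatic carbon, para to a large group, leaves the number within the scatter. At this position, then, the fluoro is not needed to hold the number at the level of compound 3. No measurement shown offers an explanation for this result.

Still open, going by these compounds, is whether removing the remaining fluoro of compound 4 would also leave the number within the scatter. Also open, on these data alone, is whether a methoxy group or a nitrile at this position would move the number beyond it.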